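Chloro Benzyl Variant of Compound 2: Expected Inhibition

The compounds below may be only part of what the source reports. "The series", "measured", "known", "first", "only" and "open" are said of these compounds alone.

The account begins with two measured compounds. Compound 1 `O=c1c2ccc([N+](=O)[O-])cc2sn1Cc1ccccc1` gives 7660 nM in an assay for inhibition of histone acetyltransferase KAT2B (Homo sapiens), read by fluorescence; a higher number here means a weaker inhibitor, a lower number a stronger inhibitor. Compound 2 `O=c1c2cccnc2sn1Cc1ccccc1` gives 23000 nM in this assay, the highest of the two numbers, and the gap to compound 1 lies beyond the usual scatter. Going by the values given here, no step between measured compounds that differ in a single place is available, so the behaviour of a substituted benzyl group is untested here.

Compound 3 `O=c1c2cccnc2sn1Cc1ccc(Cl)cc1` differs from compound 2 by one change: chloro in place of hydrogen on an aromatic carbon. Among the compounds with values here, with no comparable pair measured, the size and direction of this step cannot be read from the data; the expectation is for a change of modest size, tending toward a lower number rather than a higher one, and possibly none beyond the scatter. Compound 3 is therefore expected to give 15000 nM in this assay, within a range from 5000 nM to 45000 nM. That estimate implies a step of a 1.5-fold lower number from compound 2 to compound 3 (0.19 log units; within the scatter).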

Compound 3, half-maximal inhibitory concentration: 17500 nM
Compound 3: the middle estimate sits 1.2-fold (0.07 log units) below what was measured, within the range that was stated.
By their numbers in this assay, from the lowest: compound 1; then compounds 3 and 2 (each within the scatter of the next).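

In this assay, going by these compounds alone, the only single-place step available so far is a 1.3-fold lower number from compound 2 to compound 3 (0.12 log units; within the scatter). Within the data shown here, this gives the first direct reading of a substituent on the six-membered aromatic ring of carbon only: with chloro in place of hydrogen on an aromatic carbon, para to a large group, the two compounds cannot be told apart. On the core of compound 2, then, this one change does not produce a difference beyond the scatter, and no measurement here offers an explanation for that result.

Going by these compounds, whether an amine or a carboxylic acid at this same place would give a step beyond the scatter remains open. So does whether chloro at this place would behave the same way on the core of compound 1.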